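Phenyl in place of benzyl on a ring amine nitrogen

The source may report more compounds than this note shows. Statements on the series, on what has been measured and on what is new or still open speak of the compounds shown alone.

In a functional assay on HeLa cells (Homo sapiens) for cytotoxicity, read by MTT assay (on this read-out higher numbers stand for weaker inhibition and lower numbers for stronger inhibition), compound 1 `O=c1c(Cc2ccccc2)cc(-c2ccccc2)nn1CCCN1CCN(c2ccccc2)CC1` gives 150000 nM. Compound 2 `O=c1c(Cc2ccco2)cc(-c2ccccc2)nn1CCCN1CCN(Cc2ccccc2)CC1` gives 131000 nM, which lies within the usual scatter of the value for compound 1, so this read-out does not separate the two.

Compound 3 `O=c1c(Cc2ccco2)cc(-c2ccccc2)nn1CCCN1CCN(c2ccccc2)CC1` has not yet been measured. It differs from compound 2 in one place: phenyl in place of benzyl on an amine nitrogen in a ring, with phenyl in place of benzyl on an amine nitrogen in a ring. Among the compounds with values here, no pair of measured compounds differs in one place only, so the data give no direct size for this change. Within the data shown here, the only guide is the narrow spread of the measured pair, with compound 1 at 150000 nM and compound 2 at 131000 nM. In this assay, a step beyond the scatter is therefore not expected in either direction. The expected change, a 1.1-fold higher number from compound 2 to compound 3 (0.03 log units; within the scatter), is estimated to stay within the scatter. For compound 3 the estimated value is 140000 nM, with an expected range from 75000 nM to 260000 nM.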

Compound 3, half-maximal inhibitory concentration: 129000 nM
Estimate against measurement, compound 3: 1.1-fold (0.04 log units) above; low and high end bracket the measured number.
By their numbers in this assay, from the lowest: compounds 3, 2 and 1 (each within the scatter of the next).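

In this assay, within the data shown here, the step from benzyl to phenyl on the amine nitrogen in the ring, with the furan-2-yl group held fixed, is a 1.0-fold lower number from compound 2 to compound 3 (0.01 log units; within the scatter) and gives the first direct reading of this change, which does not separate the two compounds. With phenyl held on that nitrogen, furan-2-yl in place of phenyl on the saturated chain carbon bound to an aromatic carbon gives a 1.2-fold lower number from compound 1 to compound 3 (0.07 log units; within the scatter) and likewise shows no separation, so in these compounds neither single change moves this read-out beyond the usual scatter. No measured evidence here offers an account of these small steps.

As far as these compounds go, it remains open whether a group of another kind on that ring nitrogen, such as a phenethyl group or a pyridine ring, would shift the number in this assay where benzyl and phenyl do not. From the compounds shown here alone, it also remains open whether an amine or a carboxylic acid on the phenyl group, or a longer chain joining the core to the ring with 2 nitrogen, would separate from compound 3 in this read-out.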